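This account rests on a few compounds, and the source may have more. Where it says the series, first, only, none or still open, it means among the compounds named here.

Compound 1, `CC1(C)C2CC1[C@]1(C)OB([C@H](CCCN=C(N)N)NC(=O)c3ccc(-c4ccccc4)c(N)c3)O[C@@H]1C2`, gives 4.7 nM in an assay on isolated protein for inhibition of serine protease 1 (Homo sapiens); on this read-out lower numbers stand for stronger inhibition and higher numbers for weaker inhibition.
Compound 2, `Cc1cc(-c2ccccc2)ccc1C(=O)N[C@@H](CCCN=C(N)N)B1O[C@@H]2CC3CC(C3(C)C)[C@]2(C)O1`, gives 4.2 nM in this assay.
Compound 3, `CC(C)(C)OC(=O)Nc1cccc(-c2cccc(C(=O)N[C@@H](CCCN=C(N)N)B3O[C@@H]4CC5CC(C5(C)C)[C@]4(C)O3)c2)c1`, gives 35 nM in this assay.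

Compound 3 has the highest number of the three, and so the weakest inhibition; its distance from compound 1 and from compound 2 lies beyond the scatter in each case. Compound 4, `CC1(C)C2CC1[C@]1(C)OB([C@H](CCCN=C(N)N)NC(=O)c3cccc(-c4cccc(NS(C)(=O)=O)c4)c3)O[C@@H]1C2`, has not yet been measured. It keeps the whole of compound 3 apart from one group: methylsulfonyl in place of tert-butoxycarbonyl on a nitrogen on an aromatic ring. For the measured compounds named here, no measured pair shows this exact change, so the expectation rests on the three numbers alone. A modest step toward lower numbers, a 2.3-fold lower number from compound 3 to compound 4 (0.37 log units; beyond the scatter), is expected in this assay because compound 1 gives 4.7 nM and compound 2 gives 4.2 nM. Compound 4 is therefore estimated at 15 nM, with a likely range from 5 nM to 50 nM.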

Compound 4, inhibition constant: 3.8 nM
Compound 4: the middle estimate sits 3.9-fold (0.60 log units) above what was measured, and the stated range ends above it.
By their numbers in this assay, from the lowest: compounds 4, 2 and 1 (each within the scatter of the next); then compound 3.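

On a nitrogen on an aromatic ring, methylsulfonyl in place of tert-butoxycarbonyl gives a 9.2-fold lower number from compound 3 to compound 4 (0.96 log units; beyond the scatter) in this assay for this change. The weaker inhibition of compound 3 therefore goes with its tert-butoxycarbonyl group, since the two compounds share everything else, and this nitrogen can carry the group of 4 heavy atoms instead of the one of 7. Nothing measured here explains the step.

As far as these compounds go, whether the bare amine at this place would do as well remains open, as does the effect of an acetyl group on the same nitrogen. A sulfonyl group with a longer chain than methyl is also untested in the compounds shown.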